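Dropping the methoxy from a biaryl acid ceramidase inhibitor

A few compounds are considered here, and "the series" means these few. Any claim that something is new, unique, unknown or untested is made for them only; others in the source may bear on it.

Measured compounds:
Compound 1, `O=C(NCCCCc1ccccc1)n1c(=O)oc2ccc(Cl)cc21`: 15 nM
Compound 2, `COc1ccc(-c2ccc3c(c2)oc(=O)n3C(=O)NCCCCc2ccccc2)cc1`: 67 nM
Compound 3, `O=C(NCCCCc1ccc(F)cc1)n1c(=O)oc2ccccc21`: 75 nM

In an assay on HEK293 cells for inhibition of acid ceramidase (Homo sapiens), with a stated time of 10 min (on this read-out lower numbers stand for stronger inhibition and higher numbers for weaker inhibition), compound 2 gives the second highest of the three numbers. Its nearest neighbour is compound 3, whose value sits within the usual scatter, so no order can be read between them. Compound 1 lies furthest away, with a markedly lower number that is beyond the scatter.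

Compound 4, `O=C(NCCCCc1ccccc1)n1c(=O)oc2cc(-c3ccccc3)ccc21`, has not been measured in this assay. It differs from compound 2 by hydrogen in place of methoxy on an aromatic carbon, on an aromatic carbon of a six-membered aromatic ring of carbon only, para to a large group; read one bond further out, 4-methoxyphenyl becomes phenyl.

Among the compounds with values here, no pair of measured compounds shows this change, so the expected step of a 1.2-fold lower number from compound 2 to compound 4 (0.09 log units; within the scatter) is small and not beyond the scatter, in either direction. For compound 4 the estimated value is 55 nM, expected to fall between 18 nM and 170 nM.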

Compound 4, half-maximal inhibitory concentration: 84 nM
Compound 4: middle estimate off by 1.5-fold (0.18 log units), on the low side; the measured number falls inside the stated range.
By their numbers in this assay, from the lowest: compound 1; then compounds 2, 3 and 4 (each within the scatter of the next).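

In this assay, within the data shown here, hydrogen in place of methoxy on this six-membered aromatic ring gives a 1.3-fold higher number from compound 2 to compound 4 (0.10 log units; within the scatter), the first direct reading of this change. The 4-methoxyphenyl group and the phenyl group therefore cannot be told apart in this assay, and the methoxy is not required to reach the value of compound 2. Nothing available here explains this result.

The compounds shown leave open whether a different group at this place, such as an amine or a carboxylic acid, would shift the number beyond the scatter. Among these compounds, they also leave open how the shared core would read with a longer chain in place of the one carried by compound 4.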